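A few compounds are considered here, and "the series" means these few. Any claim that something is new, unique, unknown or untested is made for them only; others in the source may bear on it.

In a functional assay on MCF7 cells (Homo sapiens) for antiproliferative activity, read by sulforhodamine B assay, with a stated time of 72 h, tested at 10 uM (on this read-out lower numbers stand for a stronger effect and higher numbers for a weaker effect at the one concentration tested), two cores are compared. Compound 1 `COc1cc(Br)cc(/C=C/C(=O)c2ccccc2)c1O` and compound 2 `COc1cc(Br)cc(/C=C/C(=O)c2ccc(Br)cc2)c1O` share one core; compound 3 `COC(=O)C1=C(N)Oc2ccc(Br)cc2C1CC(=O)c1ccc(Br)cc1` and the not yet measured compound 4 `COC(=O)C1=C(N)Oc2ccc(Br)cc2C1CC(=O)c1ccccc1` share another. How the core of compound 2 differs from the core of compound 3 is not broken down here.

In this assay compound 2 gives 64.6%, and compound 1 gives 67%. The change between them, (hydrogen in place of bromo on an aromatic carbon), is the same change that leads from compound 3 to compound 4, hydrogen in place of bromo on an aromatic carbon: in both pairs the same group leaves from the same place. Measured once, this change made a step of a number 2.4 percentage points higher from compound 2 to compound 1 (within the scatter), a step that lies within the scatter. Compound 3 gives 72.5% in this assay, and its differences from compound 1 and from compound 2 lie within the scatter as well.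

The expectation for compound 4 rests on this single measured instance of the change. For the measured compounds named here, for compound 4 the expected step in this assay is a number 2.5 percentage points higher from compound 3 to compound 4 (within the scatter), of the same small size as the earlier one, because the one measured instance gave a number 2.4 percentage points higher from compound 2 to compound 1 (within the scatter). Going by the values given here, compound 4 is therefore estimated to give about 75% in this assay, with a likely range from 63% to 87%; with only one earlier instance to rest on, that range is kept wide.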

Compound 4, a percentage reported as activity, at one concentration (the size of the read-out at that concentration, not a potency): 107%
The estimate for compound 4 lay 32 percentage points below the measured number, outside the stated range (above it).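

In this assay, putting hydrogen in place of bromo on the core of compound 3 made a step of a number 34.5 percentage points higher from compound 3 to compound 4 (beyond the scatter), and set beside the earlier instance, the change did not carry over in size from one core to the other: the same change on two cores in this assay, a number 2.4 percentage points higher (within the scatter) from compound 2 to compound 1 and a number 34.5 percentage points higher (beyond the scatter) from compound 3 to compound 4, 32.1 percentage points apart, beyond the scatter of two such steps This shows that, for these two pairs, the size of the step from 4-bromophenyl to phenyl depends on the core that carries it, so a step measured on the core of compound 1 gave no reliable guide to the step on the core of compound 3. It does not show which part of the difference between the two cores matters, or why the steps part, and with one pair on each core it gives no general rule for the series.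

The compounds shown leave open whether chloro, methoxy or an amine in the same place would also give steps that differ between the two cores. They also leave open whether the large step from the core of compound 3 would persist at other concentrations or in other cell lines, since a single concentration in one cell line is all that is shown here.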